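Cyclopropyl for Dichlorophenyl on the Tetrazole Carbon

The source may hold more compounds than are shown below. What is called first, only, known or untested is meant among the compounds shown, and "the series" means these compounds.

Measured compounds:
compound 1 `Cc1cc(NC(=O)Cn2nnc(-c3ccccc3)n2)n(C(C)C)n1` gives 107%
compound 2 `Cc1cc(NC(=O)Cn2nnc(-c3ccccc3)n2)n(C2CCS(=O)(=O)C2)n1` gives 93%
compound 3 `Cc1cc(NC(=O)Cn2nnc(-c3cc(Cl)cc(Cl)c3)n2)n(C2CCCCC2)n1` gives 82%

These three compounds were measured in an assay on HEK293 cells for activation of Kir3.1/Kir3.2 (Homo sapiens), read by thallium flux; a lower number here means a smaller maximal response, a higher number a larger maximal response. Compound 3 stands lowest of the three: compound 2 lies nearer to it, with a value higher by a margin beyond the scatter, and compound 1 lies furthest, higher by a larger margin, also beyond the scatter.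

Compound 4 `Cc1cc(NC(=O)Cn2nnc(C3CC3)n2)n(C2CCCCC2)n1` has not been measured. It differs from compound 3 in one place: cyclopropyl in place of 3,5-dichlorophenyl on an aromatic carbon

Going by the values given here, none of the measured steps touches this position. Among the compounds with values here, the one step that has been measured, a number 14 percentage points lower from compound 1 to compound 2 (beyond the scatter), concerns the group on an aromatic nitrogen of the shared core, not the group on the tetrazole carbon, so it gives no direct guide. Compound 3 already carries the smallest value of the three, and the group that leaves is the only aromatic substituent of this kind among the measured compounds, while what enters is a much smaller ring. Within the data shown here, with no precedent to lean on, the expected step is a modest decrease, a number 17 percentage points lower from compound 3 to compound 4 (beyond the scatter), with wide uncertainty. For compound 4 the estimate in this assay is 65%, expected to fall between 40% and 95%.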

Compound 4, largest response reached (Emax), in percent of the reference or control that the assay uses: > 68%
Compound 4: only a limit was reported; the forecaster's own chance of this, stated with the estimate: 5%; at least 3 percentage points between middle value and limit.
By their numbers in this assay, from the lowest: compound 3; then compound 2; then compound 1.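

In this assay compound 4 is reported only as the limit > 68% and not as a number. The step from compound 3 to compound 4 therefore cannot be read: the limit of > 68% in this assay, at which 1 of the 4 values shown sits. The compounds shown leave open how the maximal response of compound 4 actually compares with that of compound 3, and so what cyclopropyl in place of 3,5-dichlorophenyl does to it.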